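The compounds below may be only part of what the source reports. "The series", "measured", "known", "first", "only" and "open" are said of these compounds alone.

The study compares four compounds in an ADME assay on BJ cells (Homo sapiens) for cytotoxicity, read by CellTiter-Glo and resazurin assay, with a stated time of 72 h; on this read-out higher numbers stand for an effect only at larger amounts of compound and lower numbers for an effect already at smaller amounts. Compound 1 `CC(C)N(Cc1cccc(OCCCCCC(=O)O)c1)C(=O)c1ccc(-c2cccc(C(F)(F)F)c2)cc1` bears a trifluoromethyl and a carboxy group; in this assay compound 1 gives > 26000 nM, which is a limit of the assay. Compound 2 `CC(C)N(Cc1cccc(OCCCCCC(=O)O)c1)C(=O)c1ccc(-c2cccc(Br)c2)cc1` differs from compound 1 by bromo in place of trifluoromethyl on an aromatic carbon. In this assay compound 2 gives > 26000 nM, again a limit. The step that the two limits leave unreadable from compound 1 to compound 2 is therefore not readable, since both values sit at the limit of > 26000 nM in this assay, at which 2 of the 3 values shown sit. Compound 3 `CCOC(=O)CCCCCOc1cccc(CN(C(=O)c2ccc(-c3cccc(C(F)(F)F)c3)cc2)C(C)C)c1` differs from compound 1 by ethyl in place of hydrogen on an oxygen next to a carbonyl group. In this assay compound 3 gives < 1.3 nM, likewise a limit. That difference makes the step of an at least 20000-fold lower number from compound 1 to compound 3 (4.30 log units; beyond the scatter), with compound 3 sitting at the limit of < 1.3 nM in this assay, at which 1 of the 3 values shown sits. Compound 4 `CCOC(=O)CCCCCOc1cccc(CN(C(=O)c2ccc(-c3cccc(Br)c3)cc2)C(C)C)c1` is the unmeasured partner: it differs from compound 3 by bromo in place of trifluoromethyl on an aromatic carbon, the same change as that from compound 1 to compound 2, at the same place. The step that the limit leaves unreadable from compound 3 to compound 4 is expected to be small, because compound 1 and compound 2 both sit at the limit of > 26000 nM in this assay, at which 2 of the 3 values shown sit, after this change. Compound 4 is thus expected to give about 1.2 nM, between 0.3 nM and 6 nM.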

Compound 4, half-maximal effective concentration: > 26000 nM
Compound 4: a limit, no number (the forecaster's own chance of this, stated with the estimate: 60%); at least 21000-fold (4.33 log units) between middle value and limit.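

In this assay, the change from 3-(trifluoromethyl)phenyl to 3-bromophenyl on the core of compound 3 gives an at least 20000-fold higher number from compound 3 to compound 4 (4.30 log units; beyond the scatter), so on this core the change is large. The same change on the core of compound 1 cannot be read, and neither can the step from compound 2 to compound 4, so this series shows no measured transfer of the effect from one core to the other, and the shared limit of compound 1 and compound 2 does not show that the change is without effect there. The size of the new step is also only a bound, since both of its ends are limits of the assay, and compound 4 now sits at the same limit as the two compounds bearing the carboxy group: the limit of > 26000 nM in this assay, at which 3 of the 4 values shown sit.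

From the compounds shown here alone, it remains open whether chloro or methyl in place of trifluoromethyl on the core of compound 3 would follow compound 3 or compound 4. Also open, going by these compounds, is whether a methyl or propyl group in place of the ethyl would keep the result seen for compound 3.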